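Phenoxy in Place of Benzyl in a Receptor Antagonist Series

The source may hold more compounds than are shown below. What is called first, only, known or untested is meant among the compounds shown, and "the series" means these compounds.

Compound 1, `COc1nn2cc(-c3cc4ccccc4o3)nc2s1`: 4 nM
Compound 2, `COc1cc(OCc2cccc(CCc3ccccc3)c2)c2cc(-c3cn4nc(OC)sc4n3)oc2c1`: 2.4 nM

Of the compounds shown here, two have been tested so far in a functional assay on HEK293 cells for antagonist activity at proteinase-activated receptor 4 (Homo sapiens), read by FLIPR and calcium flux, with a stated time of 30 min; a lower number here means a stronger inhibitor, a higher number a weaker inhibitor. Compound 1 gives 4 nM there, and compound 2 gives 2.4 nM. Compound 2 thus has the lower of the two numbers, but its gap to compound 1 lies within the scatter of the measurement, so the two cannot be placed in any order on this evidence.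

Compound 3, `COc1cc(OCc2cccc(COc3ccccc3)c2)c2cc(-c3cn4nc(OC)sc4n3)oc2c1`, has not yet been measured. Measured against compound 2 it shows one difference, (phenoxy in place of benzyl on a saturated chain carbon bound to an aromatic carbon). The change keeps the same count of heavy atoms and the same ring, and swaps one carbon for an oxygen that counts as a hydrogen-bond acceptor.

Among the measured compounds shown here, no measured pair shows this change, so the expectation for compound 3 rests on compound 2 alone. The step from compound 2 to compound 3 is expected to be a 1.3-fold higher number from compound 2 to compound 3 (0.10 log units; within the scatter), with no direction that would reach beyond the scatter. Compound 3 is therefore estimated at 3 nM in this assay, within a range of 1 nM to 9 nM.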

Compound 3, half-maximal inhibitory concentration: 3.2 nM
Compound 3: the middle estimate sits 1.1-fold (0.03 log units) below what was measured; the measured number falls inside the stated range.
By their numbers in this assay, from the lowest: compounds 2, 3 and 1 (each within the scatter of the next).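

The swap of benzyl for phenoxy on a saturated chain carbon bound to an aromatic carbon, which can also be read as phenethyl to phenoxymethyl, gives a 1.3-fold higher number from compound 2 to compound 3 (0.12 log units; within the scatter) in this assay and so leaves compound 2 and compound 3 indistinguishable in this assay. Among the compounds shown here, this is the first measured step at this position, and it shows that the carbon of the chain can give way to an oxygen, bringing in a hydrogen-bond acceptor while the heavy-atom count and the aromatic ring stay the same, with no change that can be read beyond the scatter. Nothing available here offers an explanation for this result.

For the compounds shown here, this single pair shows only one exchange at this position, so it cannot show how far the result extends to other linking groups or to changes elsewhere on the shared core. Going by these compounds, it remains open whether a longer chain in place of phenoxymethyl, or an amine or a carboxylic acid in place of phenoxy, would also stay within the scatter of compound 2.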